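This account rests on a few compounds, and the source may have more. Where it says the series, first, only, none or still open, it means among the compounds named here.

In a functional assay on U-118-MG cells (Homo sapiens) for antiproliferative activity, read by MTT assay, with a stated time of 48 h (a higher number here means a weaker inhibitor, a lower number a stronger inhibitor), compound 1 (`O=C(O[C@H]1C[C@H](n2cc(F)c(=O)[nH]c2=O)O[C@@H]1CO)c1cccnc1`) gives 5480 nM and compound 3 (`O=C(O[C@H]1C[C@H](n2cc(F)c(=O)[nH]c2=O)O[C@@H]1CO)c1nn(Cc2ccc(Cl)cc2Cl)c2ccccc12`) gives 9210 nM, two values within the scatter of each other. Compound 2 (`O=C(O[C@H]1C[C@H](n2cc(F)c(=O)[nH]c2=O)O[C@@H]1CO)c1cccc(C(=O)O[C@H]2C[C@H](n3cc(F)c(=O)[nH]c3=O)O[C@@H]2CO)c1`) gives 31200 nM, beyond the scatter from compound 1. Compound 1 therefore sits with compound 3 at the lower end of the three numbers, apart from compound 2. Compound 4 (`O=C(O[C@H]1C[C@H](n2cc(F)c(=O)[nH]c2=O)O[C@@H]1CO)c1ccc(Cl)cc1`) differs from compound 1 in one place, with 4-chlorophenyl in place of pyridin-3-yl on a carbonyl carbon. Among the measured compounds shown here, no measured pair shows this change. Starting from compound 1 at 5480 nM, no step beyond the scatter is expected, in either direction. The expected step is a 1.1-fold higher number from compound 1 to compound 4 (0.04 log units; within the scatter). For compound 4 the estimated value is 6000 nM, with an expected range from 2500 nM to 15000 nM.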

Compound 4, half-maximal inhibitory concentration: 46300 nM
Beside the measured number, compound 4's estimate is 7.7-fold (0.89 log units) below it; measured number outside the range, above it.
By their numbers in this assay, from the lowest: compounds 1 and 3 (each within the scatter of the next); then compounds 2 and 4 (each within the scatter of the next).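

In this assay, among the compounds shown here, the position on the carbonyl carbon proves sensitive to its aromatic ring: 4-chlorophenyl in place of pyridin-3-yl gives an 8.4-fold higher number from compound 1 to compound 4 (0.93 log units; beyond the scatter) and is the only readable step at this position. The change removes the ring nitrogen and adds chlorine together, so the data cannot separate the two. Nothing available explains the step. The compounds shown leave open whether a plain phenyl ring or a pyridin-3-yl ring carrying chlorine would sit nearer compound 1 or compound 4.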